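A few compounds are considered here, and "the series" means these few. Any claim that something is new, unique, unknown or untested is made for them only; others in the source may bear on it.

- compound 1 `O=C(CN1CCCC1)NCCNc1ccnc2cc(Cl)ccc12` gives 46400 nM
- compound 2 `O=C(CN1CCCCC1)NCCNc1ccnc2cc(Cl)ccc12` gives 23700 nM
- compound 3 `CN1CCN(CC(=O)NCCNc2ccnc3cc(Cl)ccc23)CC1` has not yet been measured

In a toxicity assay (L6 cells) for inhibition, with Rattus norvegicus as the target, read by resazurin assay, with a stated time of 70 h (a lower number here means a stronger inhibitor, a higher number a weaker inhibitor), compound 2 at 23700 nM stands within the scatter of compound 1 at 46400 nM and has no other neighbour. The change to compound 3 is 4-methylpiperazin-1-yl in place of piperidin-1-yl on a saturated chain carbon bound to a carbonyl carbon and reads 4-methylpiperazin-1-yl in place of piperidin-1-yl on a saturated chain carbon bound to a carbonyl carbon. Among the measured compounds shown here, one measured step bears on it, a ring exchange at that same place: a 2.0-fold lower number from compound 1 to compound 2 (0.29 log units; within the scatter) is the only guide. For the measured compounds named here, no measured compound carries 4-methylpiperazin-1-yl, so that guide is weak. The estimated move is a 1.3-fold higher number from compound 2 to compound 3 (0.10 log units; within the scatter) and is expected to stay inside the scatter, with no firm direction. For compound 3 the estimate is 30000 nM as the middle, with 12000 nM to 75000 nM as the expected range.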

Compound 3, half-maximal inhibitory concentration: 38100 nM
For compound 3 the middle estimate is 1.3-fold (0.10 log units) below the measured one, within the range that was stated.
By their numbers in this assay, from the lowest: compounds 2, 3 and 1 (each within the scatter of the next).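

In this assay, the step to 4-methylpiperazin-1-yl on a saturated chain carbon bound to a carbonyl carbon reads as a 1.6-fold higher number from compound 2 to compound 3 (0.21 log units; within the scatter), and the step from pyrrolidin-1-yl to the same group reads as a 1.2-fold lower number from compound 1 to compound 3 (0.09 log units; within the scatter). Each of the three ring groups now lies within the scatter of the other two, so neither the second ring nitrogen nor the added methyl separates compound 3 from compound 1 or compound 2 in this series. No supporting measurement bears on this result.

Open, on these data alone, is whether morpholin-4-yl, piperazin-1-yl with a free ring amine, an open-chain dimethylamine or a carboxylic acid at this place would give a step beyond the scatter. Also open, as far as these compounds go, is how a longer chain would read in this assay.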